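The source may report more compounds than this note shows. Statements on the series, on what has been measured and on what is new or still open speak of the compounds shown alone.

Within the data shown here, in a functional assay on HeLa cells (Homo sapiens) for antiproliferative activity, read by MTT assay, with a stated time of 3 days (on this read-out lower numbers stand for stronger inhibition and higher numbers for weaker inhibition), three compounds have numbers so far. Compound 1 (`CCOC(=O)c1sc(N/N=C(\C)C2Cc3cc(Cl)ccc3OC2=O)nc1C`) gives 9.1 nM, compound 2 (`CCOC(=O)c1sc(N/N=C(\C)C2Cc3ccccc3OC2=O)nc1C`) gives 9.1 nM, and compound 3 (`CC(=O)c1sc(N/N=C(\C)C2Cc3cc(Br)ccc3OC2=O)nc1C`) gives 9.1 nM, so compound 3 stands level with the other two at the digits reported. Compound 4 (`CCOC(=O)c1sc(N/N=C(\C)C2Cc3cc(Br)ccc3OC2=O)nc1C`) has not yet been measured. It differs from compound 3 by ethoxy in place of methyl on a carbonyl carbon, which turns acetyl into ethoxycarbonyl: ethoxy in place of methyl on a carbonyl carbon. Among the measured compounds shown here, no measured step touches this place directly. For the measured compounds named here, the only measured step, no change at the digits printed from compound 1 to compound 2 (within the scatter), is a different change, hydrogen in place of chloro on an aromatic carbon, and it stays within the scatter. The indirect evidence points the same way. Compound 2 carries the ethoxycarbonyl group and gives 9.1 nM, while compound 3 carries acetyl and gives 9.1 nM, although these two also differ in a second place. With no spread among the three values, no step beyond the scatter is expected in this assay, in either direction. The step of no change at the digits printed from compound 3 to compound 4 (within the scatter) is therefore expected to stay small. Compound 4 is estimated at 9.1 nM, with an expected range of 4.5 nM to 18 nM.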

Compound 4, half-maximal inhibitory concentration: 9.1 nM
Beside the measured number, compound 4's estimate shows no gap at the digits printed, and the stated range covers the measured number.
By their numbers in this assay, from the lowest: compounds 1, 2, 3 and 4 (each within the scatter of the next).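

Ethoxy in place of methyl on a carbonyl carbon, which turns acetyl into ethoxycarbonyl, can now be read directly with the bromo group held fixed, and in this assay it gives no change at the digits printed from compound 3 to compound 4 (within the scatter), so this place shows no response to this change in the one pair available. With ethoxycarbonyl held fixed, the aromatic carbon that earlier offered only the chloro and hydrogen comparison now offers bromo as well: bromo in place of hydrogen gives no change at the digits printed from compound 2 to compound 4 (within the scatter), and bromo in place of chloro gives no change at the digits printed from compound 1 to compound 4 (within the scatter), so hydrogen, chloro and bromo at this place are not told apart by these compounds. Nothing available bears on why neither place responds to these changes.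

As far as these compounds go, whether the same flat level would hold for a carboxylic acid, an amide or a longer ester such as butoxycarbonyl on the carbonyl carbon, or for an amine or methoxy on the aromatic carbon, remains open. Acetyl also appears here only with bromo, so it is open whether acetyl to ethoxycarbonyl would read the same with hydrogen or chloro on the aromatic carbon.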